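Chromane ethers as fatty acid receptor 1 agonists: triazole step

A few compounds are considered here, and "the series" means these few. Any claim that something is new, unique, unknown or untested is made for them only; others in the source may bear on it.

Measured so far:
compound 1 `CS(=O)(=O)CCCOc1ccc2c(c1)OC(COc1ccc(CCC(=O)O)c(F)c1)CC2` — 36300 nM
compound 2 `O=C(O)CCc1ccc(OCC2COc3ccc(Br)cc3O2)cc1F` — 2240 nM
compound 3 `CCOC(CC(=O)O)c1ccc(OCC2COc3ccc(Cl)cc3O2)cc1` — 640 nM

In a functional assay on HEK293 cells for agonist activity at Free fatty acid receptor 1 (Homo sapiens), read by fluorescence and calcium flux, with a stated time of 10 min (a higher number here means that more compound is needed for the effect, a lower number that less compound is needed), compound 3 gives 640 nM, the lowest of the three numbers. Its nearest neighbour is compound 2, which in this assay gives 2240 nM; that gap is beyond the scatter, so compound 3 needs clearly less compound than compound 2. Compound 1, with 36300 nM in this assay, is far away from compound 3, again beyond the scatter. Among the measured compounds shown here, no pair among the three differs in one place only, so no single measured step exists to lean on.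

The next compound is compound 4 `Cn1nncc1C(CC(=O)O)c1ccc(OCC2COc3ccc(Cl)cc3O2)cc1`. It differs from compound 3 in one spot: 1-methyl-1H-1,2,3-triazol-5-yl in place of ethoxy on a saturated chain carbon bound to an aromatic carbon and a saturated chain carbon. The shared core and the acid chain are kept.

With no measured step of this kind in the set, the direction is open. The change is expected to be modest, within or only just beyond the scatter, and if anything toward a lower number; the expected step of a 1.6-fold lower number from compound 3 to compound 4 (0.20 log units; within the scatter) states this. Compound 4 is therefore estimated at about 400 nM in this assay, with a range from 100 nM to 1600 nM.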

Compound 4, half-maximal effective concentration: 3870 nM
For compound 4 the middle estimate is 9.7-fold (0.99 log units) below the measured one; the whole stated range lies below it.
By their numbers in this assay, from the lowest: compound 3; then compounds 2 and 4 (each within the scatter of the next); then compound 1.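

In this assay, among the compounds shown here, the saturated chain carbon bound to an aromatic carbon and a saturated chain carbon proves sensitive to its substituent: placing 1-methyl-1H-1,2,3-triazol-5-yl there in place of ethoxy gives a 6.0-fold higher number from compound 3 to compound 4 (0.78 log units; beyond the scatter), and this is the first step that differs in one place only. For the compounds shown here, the single change alters several things at once, since 6 heavy atoms replace 3, a five-membered aromatic ring with 3 hetero atoms enters where no ring stood, and 3 hydrogen-bond acceptors replace 1, so the step alone cannot assign the higher number to any one of these features. Nothing available here bears on why this exchange raises the number. What the compounds shown leave open is whether the ring as such or its nitrogen atoms go with the change, a question that a phenyl ring or a simple methoxy group on the same carbon would help to separate. From the compounds shown here alone, it also remains open whether the step would carry over to the other cores, since it rests on one pair of compounds.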